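A few compounds are considered here, and "the series" means these few. Any claim that something is new, unique, unknown or untested is made for them only; others in the source may bear on it.

Measured compounds in a functional assay (aorta) for antagonist activity, with Oryctolagus cuniculus as the target; on this read-out higher numbers stand for weaker inhibition and lower numbers for stronger inhibition:
compound 1, `CCCCc1ccc(CNC(C)=O)c(=O)n1Cc1ccc(-c2ccccc2-c2nn[nH]n2)cc1`: 3 nM
compound 2, `CCCCc1ccc(CN(Cc2ccccc2)S(C)(=O)=O)c(=O)n1Cc1ccc(-c2ccccc2-c2nn[nH]n2)cc1`: 2 nM

Within the data shown here, compound 1 carries the higher of the two numbers, but its only neighbour is compound 2 at a 1.5-fold lower number from compound 1 to compound 2 (0.18 log units; within the scatter), so the two compounds are not distinguished in this assay.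

Compound 3, `CCCCc1cccc(=O)n1Cc1ccc(-c2ccccc2-c2nn[nH]n2)cc1`, awaits measurement in this assay. Its difference from compound 1: hydrogen in place of acetamidomethyl on an aromatic carbon

Among the measured compounds shown here, the single measured step, a 1.5-fold lower number from compound 1 to compound 2 (0.18 log units; within the scatter), exchanges one substituent for another while the acetamidomethyl carbon stays in place. It shows that the position accepts a different group. Replacement of the whole side chain by hydrogen is not tested by it. For the measured compounds named here, no measured pair covers that. The expectation is therefore a step toward a higher number, moderate and uncertain, a 3.3-fold higher number from compound 1 to compound 3 (0.52 log units; beyond the scatter). For compound 3 the estimate in this assay is 10 nM, with a range from 2 nM to 50 nM.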

Compound 3, half-maximal inhibitory concentration: 4 nM
Beside the measured number, compound 3's estimate is 2.5-fold (0.40 log units) above it; measured number inside the range.
By their numbers in this assay, from the lowest: compounds 2, 1 and 3 (each within the scatter of the next).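

Hydrogen in place of acetamidomethyl on this aromatic carbon gives a 1.3-fold higher number from compound 1 to compound 3 (0.12 log units; within the scatter) in this assay and so does not separate the two compounds. The earlier step changed only the substituent on a retained chain carbon, whereas this one removes the whole side chain, with its 5 heavy atoms, and still leaves the number within the scatter. The acetamidomethyl group is therefore not required for the low nanomolar level seen for compound 1 in this assay, though nothing available explains this tolerance.

Still open, as far as these compounds go, is whether a group of another kind on this carbon, such as a primary amine, a carboxylic acid or a longer alkyl chain, would move the number beyond the scatter. From the compounds shown here alone, whether the same tolerance holds outside this assay also remains open.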